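Chloro in place of trifluoromethyl: an expected small step

The compounds below may be only part of what the source reports. "The series", "measured", "known", "first", "only" and "open" are said of these compounds alone.

Of the compounds shown here, two have been measured so far. Compound 1, `O=C(Nc1cccc(-n2cc(-c3ccncc3)c(-c3cc(O)cc(Cl)c3)n2)c1)Nc1ccc(Cl)c(Cl)c1`, was tested in a functional assay on A549 cells (Homo sapiens) for inhibition, read by sulforhodamine B assay, with a stated time of 48 h, tested at 0.01 uM (a higher number here means a weaker effect of the compound at the concentration tested, a lower number a stronger effect), and compound 1 gives 96% there. Compound 2, `COc1cc(Cl)cc(-c2nn(-c3cccc(NC(=O)Nc4ccc(Cl)c(C(F)(F)F)c4)c3)cc2-c2ccncc2)c1`, gives 97% in this assay. Of these two numbers compound 2 holds the higher one, but the gap to compound 1 lies within the scatter, so the two readings count as the same.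

Compound 3, `COc1cc(Cl)cc(-c2nn(-c3cccc(NC(=O)Nc4ccc(Cl)c(Cl)c4)c3)cc2-c2ccncc2)c1`, differs from compound 2 in a single place: chloro in place of trifluoromethyl on an aromatic carbon. For the measured compounds named here, no pair of measured compounds differing in only one place is available, so the expectation rests on the two values in hand, which agree closely. The step expected in this assay is accordingly small, a number 1 percentage points lower from compound 2 to compound 3 (within the scatter), and in neither direction beyond the scatter. Compound 3 is estimated at 96%, with a likely range from 87% to 102%.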

Compound 3, a percentage reported as activity, at one concentration (the size of the read-out at that concentration, not a potency): 99%
Compound 3: the middle estimate sits 3 percentage points below what was measured; the measured number falls inside the stated range.
By their numbers in this assay, from the lowest: compounds 1, 2 and 3 (each within the scatter of the next).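

In this assay, chloro in place of trifluoromethyl on this aromatic carbon, ortho to a chloro group, gives a number 2 percentage points higher from compound 2 to compound 3 (within the scatter), so at this one concentration the reading does not tell these two groups apart. For the compounds shown here, the first one-place comparison on the oxygen, methyl in place of hydrogen, gives a number 3 percentage points higher from compound 1 to compound 3 (within the scatter), and this change likewise stays inside the usual spread of repeat measurements. No other measurement here offers an explanation for either result.

Open, as far as these compounds go, is whether an amine or a carboxylic acid at the trifluoromethyl position, or an ethyl group or longer chain on the oxygen, would shift the reading beyond the scatter. Also open, from the compounds shown here alone, is whether these two changes would remain as small at a higher concentration of the compounds.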